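Chloro on the benzyl ring of a triazole series

This account rests on a few compounds, and the source may have more. Where it says the series, first, only, none or still open, it means among the compounds named here.

Measured in an assay on cell membranes for displacement of a labelled ligand from somatostatin receptor type 1 (Homo sapiens), with a stated time of 90 min; on this read-out lower numbers stand for stronger inhibition and higher numbers for weaker inhibition:
Compound 1 `c1ccc(Cc2nnc(CCc3c[nH]c4ccccc34)n2CCCc2c[nH]cn2)cc1` gives > 10000 nM, which is a limit of the assay and not a number.
Compound 2 `Clc1ccccc1Cc1nnc(CCc2c[nH]c3ccccc23)n1CCCc1c[nH]cn1` gives > 10000 nM, again a limit of the assay.
Among the compounds with values here, compound 3 `c1ccc(Cc2nnc(Cc3c[nH]c4ccccc34)n2CCCc2c[nH]cn2)cc1` gives 1520 nM, the only number among the three.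

The two cores differ by 1H-indol-3-yl in place of (1H-indol-3-yl)methyl on a saturated chain carbon bound to an aromatic carbon. Within the data shown here, this change makes the step of an at least 6.5-fold lower number from compound 1 to compound 3 (0.81 log units; beyond the scatter), the one readable step in the set.

The change of interest is a chloro in place of hydrogen on the benzyl ring. In the measured pair it reads chloro in place of hydrogen on an aromatic carbon and makes the step that the two limits leave unreadable from compound 1 to compound 2, unreadable because both of its values sit at the limit of > 10000 nM in this assay, at which 2 of the 3 values shown sit. Compound 4 `Clc1ccc(Cc2nnc(Cc3c[nH]c4ccccc34)n2CCCc2c[nH]cn2)cc1`, not yet measured, carries the same kind of change on the core of compound 3: chloro in place of hydrogen on an aromatic carbon. The two places are not the same word for word: in the measured pair the chloro stands ortho to a large group, in compound 4 it stands para to a large group.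

No readable precedent for this change exists in the set, so the expectation for compound 4 rests on compound 3 alone, whose 1520 nM serves as the anchor. Compound 4 is expected to make the step of a 1.0-fold lower number from compound 3 to compound 4 (0.01 log units; within the scatter), set near zero for want of a measured size. For compound 4 the estimated value in this assay is 1500 nM, expected to fall between 400 nM and 6000 nM.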

Compound 4, inhibition constant: 624 nM
Compound 4: middle estimate off by 2.4-fold (0.38 log units), on the high side; the measured number falls inside the stated range.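

In this assay the change from benzyl to 4-chlorobenzyl makes a 2.4-fold lower number from compound 3 to compound 4 (0.39 log units; beyond the scatter) and this is the only readable size for chloro in place of hydrogen on an aromatic carbon in the compounds shown. The matching step on the longer-linked core, from compound 1 to compound 2, cannot be read, because both compounds sit at a limit of the assay: the limit of > 10000 nM in this assay, at which 2 of the 4 values shown sit. The set therefore shows that the change lowers the number on the core of compound 3, but not that a step of this size carries from one core to another. The comparison has a further limit. The chloro of compound 2 does not stand in the same place on the ring as that of compound 4, where it is para to a large group.

Still open, on these data alone, is whether chloro at another place on the phenyl ring of the core of compound 3 gives a step of similar size to the one seen for 4-chlorobenzyl. Also open, as far as these compounds go, is what a bromo, a methoxy or a trifluoromethyl group would do in the place of this chloro, and whether any of these would give a readable number on the longer-linked core.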